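Pyridin-2-yl in Place of 2-Bromophenyl on an Amine

The source may hold more compounds than are shown below. What is called first, only, known or untested is meant among the compounds shown, and "the series" means these compounds.

Compound 1 `COC(=O)c1sc2cc(Nc3ccccc3Br)cnc2c1N`: 28900 nM
Compound 2 `COC(=O)c1sc2cc(Nc3ccc(F)cc3Br)cnc2c1N`: 28900 nM

In a functional assay on MCF7 cells (Homo sapiens) for inhibition, read by sulforhodamine B assay, with a stated time of 48 h (on this read-out higher numbers stand for weaker inhibition of growth and lower numbers for stronger inhibition of growth), compound 1 gives 28900 nM and compound 2 gives 28900 nM; the step of no change at the digits printed from compound 1 to compound 2 (within the scatter) leaves compound 1 level with compound 2. Compound 3 `COC(=O)c1sc2cc(Nc3ccccn3)cnc2c1N` differs from compound 1 by pyridin-2-yl in place of 2-bromophenyl on a nitrogen on an aromatic ring. For the measured compounds named here, no measured step touches this group; the single known step, no change at the digits printed from compound 1 to compound 2 (within the scatter), only shows that the core tolerates a small change on the aryl ring without moving beyond the scatter. For compound 3 a step of about a 1.1-fold higher number from compound 1 to compound 3 (0.04 log units; within the scatter) is therefore expected. Compound 3 is estimated at 32000 nM, with a range from 10000 nM to 100000 nM.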

Compound 3, concentration for 50% growth inhibition: > 150000 nM
Compound 3 gave a limit, no number; the forecaster's own chance of this, stated with the estimate: 25%; at least 4.6-fold (0.67 log units) between middle value and limit.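

The aryl group on this nitrogen is not free to change as the earlier fluoro step suggested: pyridin-2-yl in place of 2-bromophenyl gives an at least 5.1-fold higher number from compound 1 to compound 3 (0.71 log units; beyond the scatter) in this assay. Compound 3 gives > 150000 nM, which is a limit and not a number, so this step has a floor but no measured size: the limit of > 150000 nM in this assay, at which 1 of the 3 values shown sits.

The compounds shown change the ring nitrogen and the bromine together and do not separate them. As far as these compounds go, whether a plain phenyl group, or chlorine in place of the bromine, would stay level with compound 1 remains open.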